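The compounds below may be only part of what the source reports. "The series", "measured", "known", "first", "only" and "open" are said of these compounds alone.

Working notes on the series. For the measured compounds named here, in an ADME assay on Vero cells (Chlorocebus sabaeus) for cytotoxicity, read by neutral red uptake, with a stated time of 48 h (a lower number here means a stronger inhibitor, a higher number a weaker inhibitor), compound 1 `Clc1ccc2c(NCCn3cnc4c(N5CCN(c6ccccc6)CC5)nc(Cl)nc43)ccnc2c1` gives 4040 nM, the only full number so far. On these data alone, compound 2 `Clc1ccc2c(NCCCn3cnc4c(N5CCCC5)nc(Cl)nc43)ccnc2c1` gives > 10700 nM, which is a limit of the assay and not a number, so its true position is unknown. Compound 3 `CCN1CCN(c2nc(Cl)nc3c2ncn3CCCNc2ccnc3cc(Cl)ccc23)CC1` is the next to be read, and it differs from compound 2 by one exchange: 4-ethylpiperazin-1-yl in place of pyrrolidin-1-yl on an aromatic carbon. Going by the values given here, no measured step in this assay isolates this change. Among the compounds with values here, the only guide is compound 1 at 4040 nM, which also carries a six-membered non-aromatic ring with 2 hetero atoms but differs from compound 3 in more than one place. A modest move towards a lower number is therefore expected, and the estimated at least 1.3-fold lower number from compound 2 to compound 3 (0.12 log units; that floor lies within the scatter) is uncertain. For compound 3 the estimated value is 8000 nM, with an expected range of 3000 nM to 20000 nM.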

Compound 3, half-maximal inhibitory concentration: > 9830 nM
Compound 3 ended at the assay's limit; the forecaster's own chance of this, stated with the estimate: 35%; middle value at least 1.2-fold (0.08 log units) away from the limit.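

Compound 2 and compound 3 both stand at a limit of this assay, and no step can be read between them. The compounds shown leave open where the true values of compound 2 and compound 3 lie, and whether 4-ethylpiperazin-1-yl in place of pyrrolidin-1-yl changes the number at all.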